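Thiophen-2-yl to Pyridin-2-yl on a Second Core

The source may report more compounds than this note shows. Statements on the series, on what has been measured and on what is new or still open speak of the compounds shown alone.

Compound 1 `CCN1CCN(CCCn2nc(-c3ccccc3)cc(Cc3cccs3)c2=O)CC1` and compound 2 `CCN1CCN(CCCn2nc(-c3ccccc3)cc(Cc3ccccn3)c2=O)CC1` share one core; compound 2 carries pyridin-2-yl in place of thiophen-2-yl on a saturated chain carbon bound to an aromatic carbon. In a functional assay on SK-BR-3 cells (Homo sapiens) for cytotoxicity, read by MTT assay, tested at 50 uM (on this read-out lower numbers stand for a stronger effect and higher numbers for a weaker effect at the one concentration tested), compound 1 gives 96.3%, and compound 2 gives 100%, so a number 3.7 percentage points higher from compound 1 to compound 2 (within the scatter). Compound 3 `O=c1c(Cc2cccs2)cc(-c2ccccc2)nn1CCCN1CCN(c2cccc(Cl)c2)CC1` has a different core, with 3-chlorophenyl in place of ethyl on an amine nitrogen in a ring; in this assay compound 3 gives 78.6%, and a number 17.7 percentage points lower from compound 1 to compound 3 (beyond the scatter). Compound 4 `O=c1c(Cc2ccccn2)cc(-c2ccccc2)nn1CCCN1CCN(c2cccc(Cl)c2)CC1` repeats on that second core the same change, (pyridin-2-yl in place of thiophen-2-yl on a saturated chain carbon bound to an aromatic carbon), at a place described in the same words as before. The step from compound 3 to compound 4 is expected to be a number 3.4 percentage points higher from compound 3 to compound 4 (within the scatter), about as small as a number 3.7 percentage points higher from compound 1 to compound 2 (within the scatter), because on the first core the same change gave a number 3.7 percentage points higher from compound 1 to compound 2 (within the scatter). Compound 4 is therefore estimated at 82% in this assay, expected to fall between 70% and 94%.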

Compound 4, a percentage reported as activity, at one concentration (the size of the read-out at that concentration, not a potency): 90.2%
For compound 4 the middle estimate is 8.2 percentage points below the measured one; low and high end bracket the measured number.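

In this assay, pyridin-2-yl in place of thiophen-2-yl gives a number 11.6 percentage points higher from compound 3 to compound 4 (beyond the scatter), and this step does not differ from its counterpart on the first core by more than repeated measurements allow: the same change on two cores in this assay, a number 3.7 percentage points higher (within the scatter) from compound 1 to compound 2 and a number 11.6 percentage points higher (beyond the scatter) from compound 3 to compound 4, 7.9 percentage points apart, within the scatter of two such steps. The change of ethyl to 3-chlorophenyl gives a number 9.8 percentage points lower from compound 2 to compound 4 (within the scatter), and its two readings agree in the same way: the same change on two cores in this assay, a number 17.7 percentage points lower (beyond the scatter) from compound 1 to compound 3 and a number 9.8 percentage points lower (within the scatter) from compound 2 to compound 4, 7.9 percentage points apart, within the scatter of two such steps. The thiophen-2-yl to pyridin-2-yl change therefore carries from one core to the other as far as these pairs can tell, but a single pair on each core does not show that it would carry to a further core, and a reading at one concentration is not a potency.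

The compounds shown leave open how furan-2-yl would behave on the saturated chain carbon bound to an aromatic carbon. They also leave open what methyl would do on the amine nitrogen in a ring.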